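Chloro on the Phenyl Sulfone of a Urea Series

The source may report more compounds than this note shows. Statements on the series, on what has been measured and on what is new or still open speak of the compounds shown alone.

Of the compounds shown here, two of one urea series have been measured in an assay on isolated protein for activation of Nicotinamide phosphoribosyltransferase (Homo sapiens); on this read-out lower numbers stand for an effect already at smaller amounts and higher numbers for an effect only at larger amounts of compound. Compound 1 `O=C(NCc1ccncc1)Nc1ccc(S(=O)(=O)N2CCc3ccccc3C2)cc1` carries a 1,2,3,4-tetrahydroisoquinolin-2-yl group on the sulfonyl sulfur, and in this assay compound 1 gives 142 nM. Compound 2 `O=C(NCc1ccncc1)Nc1ccc(S(=O)(=O)c2ccccc2)cc1` carries a phenyl there instead, and in this assay compound 2 gives 85 nM. The step of a 1.7-fold lower number from compound 1 to compound 2 (0.22 log units; within the scatter) is the only measured one, and it does not separate the two compounds. Compound 2 therefore holds the lower of the two numbers, but the gap to compound 1 is within the scatter, so neither compound can be called the more potent.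

Compound 3 `O=C(NCc1ccncc1)Nc1ccc(S(=O)(=O)c2ccc(Cl)cc2)cc1` is not yet measured. It differs from compound 2 in one place: chloro in place of hydrogen on an aromatic carbon. Within the data shown here, no measured step involves adding a chloro to an aromatic ring, so nothing in the data speaks to the size or direction of this change. Given the value of compound 2 at 85 nM, the expected step of a 1.1-fold lower number from compound 2 to compound 3 (0.05 log units; within the scatter) is none beyond the scatter. Compound 3 is thus estimated at 75 nM, with a range from 30 nM to 190 nM.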

Compound 3, half-maximal effective concentration: 126 nM
Compound 3: the middle estimate sits 1.7-fold (0.23 log units) below what was measured; the range from low to high includes it.
By their numbers in this assay, from the lowest: compounds 2, 3 and 1 (each within the scatter of the next).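

In this assay, chloro in place of hydrogen on an aromatic carbon of the phenyl sulfone, para to a large group, shows a 1.5-fold higher number from compound 2 to compound 3 (0.17 log units; within the scatter), so adding this one chlorine atom at this position produces no change that can be told apart from the usual spread of repeated measurements. The 4-chlorophenyl group on the sulfonyl sulfur also cannot be separated from the 1,2,3,4-tetrahydroisoquinolin-2-yl group, with a 1.1-fold lower number from compound 1 to compound 3 (0.05 log units; within the scatter), and so the three groups seen on the sulfur so far give numbers that lie within the scatter of one another. No measured evidence is available that would explain this outcome.

A single chloro cannot show whether this position is insensitive to substitution in general, and a methoxy, an amine or a carboxylic acid in the same place could still give a number clearly different from that of compound 2. As far as these compounds go, it also remains open whether a chloro elsewhere on the same ring, or a second chloro added to the ring of compound 3, would move the number beyond the scatter.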